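This account rests on a few compounds, and the source may have more. Where it says the series, first, only, none or still open, it means among the compounds named here.

Measured compounds:
Compound 1, `CCOC(=O)C1CCCCN1S(=O)(=O)c1ccc(S(=O)(=O)N(CC)CC)cc1`: > 3000 nM
Compound 2, `CC(C)c1noc(N2CCN(C(=O)[C@@H]3CCCN(S(=O)(=O)c4ccc(S(=O)(=O)NC5CC5)cc4)C3)CC2)n1`: 300 nM
Compound 3, `CCOC(=O)[C@@H]1CCCN(S(=O)(=O)c2cccc(S(=O)(=O)N(CC)CC)c2)C1`: > 10000 nM

The three compounds were tested in a functional assay on MIA PaCa-2 cells (Homo sapiens) for inhibition, read by MTT assay, with a stated time of 3 days; on this read-out higher numbers stand for weaker inhibition and lower numbers for stronger inhibition. Compound 2 is the only one of them to give a number, and in this assay compound 2 gives 300 nM. Compound 1 gives only a limit, > 3000 nM, so its potency is not known beyond that. Compound 3 likewise gives only a limit, > 10000 nM. Among the three, then, compound 2 is the single fixed point, and the other two mark where the read-out stops reporting a number, as noted for the limit of > 10000 nM in this assay, at which 1 of the 3 values shown sits, and (the limit of > 3000 nM in this assay, at which 1 of the 3 values shown sits).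

Compound 4, `CC(C)c1noc(N2CCN(C(=O)[C@@H]3CCCN(S(=O)(=O)c4ccc(S(=O)(=O)C(C)C)cc4)C3)CC2)n1`, has not yet been measured in this assay. It differs from compound 2 in one place: isopropyl in place of cyclopropylamino on a sulfonyl sulfur. Among the compounds with values here, no measured pair among the three compounds isolates this change, so there is no directly comparable step to lean on.

The expectation is a moderate weakening, beyond the usual scatter but not large: the step from compound 2 to compound 4 is estimated at a 2.3-fold higher number from compound 2 to compound 4 (0.37 log units; beyond the scatter). On that basis compound 4 is expected to give about 700 nM, with a plausible range from 250 nM to 3000 nM.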

Compound 4, half-maximal inhibitory concentration: 30 nM
Compound 4: middle estimate off by 23-fold (1.37 log units), on the high side, and the stated range ends above it.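

In this assay, isopropyl in place of cyclopropylamino on a sulfonyl sulfur brings a 10-fold lower number from compound 2 to compound 4 (1.00 log units; beyond the scatter). Within the data shown here, this is the first step that isolates a change at this place, and it shows that the hydrogen-bond donor and the three-membered ring of cyclopropylamino can both leave this sulfonyl sulfur with a gain rather than a loss in this read-out, even though the change touches only one group on the shared core. Nothing in the information at hand gives a reason for a step of this size.

Because the nitrogen and the ring leave together, this one step cannot tell which of the two departures goes with the gain, and a cyclopropyl group set directly on the sulfonyl sulfur or an isopropylamino group in the same place would be needed to part them. On these data alone, it also remains open how far the gain extends to other groups on this sulfur, such as a methyl, a tert-butyl or a morpholine, and whether it would hold on a different core.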